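This account rests on a few compounds, and the source may have more. Where it says the series, first, only, none or still open, it means among the compounds named here.

In this assay a functional assay on WM 266-4 cells (Homo sapiens) for antiproliferative activity, read by MTT assay, with a stated time of 48 h (a higher number here means a weaker inhibitor of growth, a lower number a stronger inhibitor of growth), compound 2 `COc1cccc(C2=NN(C(=S)Nc3ccccc3)C(c3ccc4c(c3)OCCO4)C2)c1` gives 1380 nM. Among the compounds with values here, that is the only firm number so far. Compound 1 `S=C(Nc1ccccc1)N1N=C(c2ccc(Cl)cc2)CC1c1ccc2c(c1)OCCO2` reaches only a limit of the assay, > 200000 nM, and the limit of > 200000 nM in this assay, at which 1 of the 2 values shown sits, is therefore all that is known of it. Within the data shown here, the one measured step, an at least 140-fold lower number from compound 1 to compound 2 (2.16 log units; beyond the scatter), shows that swapping the aromatic group on the carbon with a double bond to nitrogen can move the result a long way, though with a limit on one side the true size of that move is open.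

Compound 3 `S=C(Nc1ccccc1)N1N=C(c2cccs2)CC1c1ccc2c(c1)OCCO2` changes the same position again: thiophen-2-yl in place of 3-methoxyphenyl on a carbon with a double bond to nitrogen. Among the measured compounds shown here, no measured pair shows what a thiophen-2-yl does here, so the only guidance is that this position has already given a large shift once, which argues for a wide range in either direction rather than a confident direction. Compound 3 is expected to give about 5000 nM, somewhere between 700 nM and 60000 nM. That expectation corresponds to a 3.6-fold higher number from compound 2 to compound 3 (0.56 log units; beyond the scatter), an estimate rather than a measurement.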

Compound 3, concentration for 50% growth inhibition: 154000 nM
Beside the measured number, compound 3's estimate is 31-fold (1.49 log units) below it; the whole stated range lies below it.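

In this assay thiophen-2-yl in place of 3-methoxyphenyl gives a 110-fold higher number from compound 2 to compound 3 (2.05 log units; beyond the scatter) and so the large shift at this position now appears with a second group and not only with 4-chlorophenyl. Of the three groups shown on the carbon with a double bond to nitrogen, only 3-methoxyphenyl gives a low number, and replacing it with either of the other two costs a great deal of activity, so the position is far from indifferent to which aromatic ring it carries. Compound 1 stands at a limit. The remaining step, an at least 1.2-fold lower number from compound 1 to compound 3 (0.11 log units; that floor lies within the scatter), therefore cannot be read as a real difference, and the two groups that give weak results cannot be put in order: the limit of > 200000 nM in this assay, at which 1 of the 3 values shown sits.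

As far as these compounds go, what remains open is which part of 3-methoxyphenyl matters, the six-membered ring itself or the methoxy group on it. A plain phenyl ring, a phenyl ring carrying a hydroxyl group or an amine, or a furan-2-yl ring at the same position would help to separate these possibilities, and none of them can be predicted from the compounds shown.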